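Trimming the amide chain of a luciferase-reporter GnRH antagonist

This account rests on a few compounds, and the source may have more. Where it says the series, first, only, none or still open, it means among the compounds named here.

Compound 1, with the structure `C#CCNC(=O)CN(Cc1ccccc1)Cc1c(-c2ccc(NC(=O)NCC)cc2)nc2n(Cc3c(F)cccc3F)cc(C(=O)OCC)c(=O)n12`, was tested in a functional assay on CHO cells for antagonist activity at Gonadotropin-releasing hormone receptor (Homo sapiens), read by a luciferase reporter, with a stated time of 30 min (a higher number here means a weaker inhibitor, a lower number a stronger inhibitor), where it gave 1000 nM. Going by the values given here, compound 1 holds the highest number of the two measured so far. Its nearest neighbour is compound 2, `CCNC(=O)Nc1ccc(-c2nc3n(Cc4c(F)cccc4F)cc(C(=O)OCC)c(=O)n3c2CN(CC(=O)NCc2cn(CCN=[N+]=[N-])nn2)Cc2ccccc2)cc1`, which in this assay gave 724 nM; the step of a 1.4-fold lower number from compound 1 to compound 2 (0.14 log units; within the scatter) came from putting a 1-(2-azidoethyl)-1H-1,2,3-triazol-4-yl in place of ethynyl on a saturated chain carbon bound to an amide-type nitrogen.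

Compound 3, `CCNC(=O)Nc1ccc(-c2nc3n(Cc4c(F)cccc4F)cc(C(=O)OCC)c(=O)n3c2CN(C)Cc2ccccc2)cc1`, has not yet been measured. It differs from compound 1 by hydrogen in place of propargylcarbamoyl on a saturated chain carbon bound to an amine nitrogen. Among the compounds with values here, only the step from compound 1 to compound 2 bears on this, and only loosely: it shows the far end of that chain can be altered greatly with no effect beyond the scatter, but nothing measured shows what removing the whole chain does. Compound 3 is therefore expected to stay close, with the step of a 1.1-fold higher number from compound 1 to compound 3 (0.04 log units; within the scatter), and its estimated value is 1100 nM, within 300 nM to 4000 nM.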

Compound 3, half-maximal inhibitory concentration: 70.8 nM
The estimate for compound 3 lay 16-fold (1.19 log units) above the measured number, outside the stated range (below it).
By their numbers in this assay, from the lowest: compound 3; then compounds 2 and 1 (each within the scatter of the next).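

In this assay, replacing the whole propargylcarbamoyl with hydrogen on a saturated chain carbon bound to an amine nitrogen, which turns (propargylcarbamoyl)methyl into methyl, gives a 14-fold lower number from compound 1 to compound 3 (1.15 log units; beyond the scatter), a large step beyond the scatter. The earlier step, a 1.4-fold lower number from compound 1 to compound 2 (0.14 log units; within the scatter), changed only the far end of the chain and left the number within the scatter, so it gave no sign that this site could matter so much; the new result shows that keeping or removing the chain as a whole makes a clear difference, even though altering its end did not. Nothing measured here explains why the simple methyl compound gives the much lower number.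

The compounds shown jump from methyl straight to chains that carry an amide, so it remains open whether the number rises gradually with chain length or depends on the amide itself. An ethyl or a 2-hydroxyethyl group at this site, or a short chain ending in a carboxylic acid or an amine, would help separate these possibilities.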